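This account rests on a few compounds, and the source may have more. Where it says the series, first, only, none or still open, it means among the compounds named here.

Working notes on the series.

Of the compounds shown here, three have been measured in an in vitro functional assay on HEK ts201 cells for antagonist activity at Neuronal acetylcholine receptor; alpha3/beta4 (Homo sapiens), read by fluorescence and calcium flux; a lower number here means a stronger inhibitor, a higher number a weaker inhibitor. Compound 1 `O=C(OCc1ccccc1-c1ccccc1)C1CCCN(CCCc2ccccc2)C1` gives 10200 nM. Compound 2 `O=C(Nc1ccccn1)c1ccccc1-c1ccccc1` gives 17500 nM. Compound 3 `c1ccc(CCCN2CCCC(COCc3ccccc3-c3ccccc3)C2)cc1` gives 15500 nM. Of the three numbers, compound 2 gives the highest, but its gap to compound 3 and its gap to compound 1 both lie within the usual scatter of this assay, so the three compounds cannot be separated on these data.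

Compound 4 `O=C(NCc1ccccc1)c1ccccc1-c1ccccc1` has not yet been measured. Relative to compound 2, the change is benzyl in place of pyridin-2-yl on an amide-type nitrogen. For the measured compounds named here, no measured pair shows this change, so there is no direct precedent for its effect.

Going by the values given here, with compound 2 at 17500 nM and no measured step to draw on, the step expected from compound 2 to compound 4 in this assay is a 1.2-fold lower number from compound 2 to compound 4 (0.07 log units; within the scatter), that is, no change beyond the scatter in either direction. Compound 4 is accordingly estimated at 15000 nM, with a range from 5000 nM to 45000 nM.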

Compound 4, half-maximal inhibitory concentration: 7600 nM
The estimate for compound 4 lay 2.0-fold (0.30 log units) above the measured number; measured number inside the range.
By their numbers in this assay, from the lowest: compounds 4, 1, 3 and 2 (each within the scatter of the next, the first and the last beyond it).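

In this assay, for the compounds shown here, the substituent on the amide-type nitrogen gives the first step beyond the scatter, though a modest one: a 2.3-fold lower number from compound 2 to compound 4 (0.36 log units; beyond the scatter), with benzyl in place of pyridin-2-yl. The position therefore responds to this change, but the change alters the ring's hetero atom and the heavy-atom count together, and this single step cannot separate the two. Nothing at hand accounts for the size or direction of the step.

Open, on these data alone, is whether phenyl, a ring of carbon only, or pyridin-2-ylmethyl, which keeps the ring nitrogen on the benzyl-like frame, would follow compound 4 or compound 2. Also open, as far as these compounds go, is how a longer chain such as 2-phenylethyl would read at this nitrogen.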